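A few compounds are considered here, and "the series" means these few. Any claim that something is new, unique, unknown or untested is made for them only; others in the source may bear on it.

Compound 1, with the structure `CCOC(=O)C1=C(NN=C(C(C)=O)C(C)=O)Nc2[nH]nc(C)c2C1c1ccc(N(C)C)cc1`, gives 9740 nM in a functional assay on MCF7 cells (Homo sapiens) for inhibition, read by MTT assay, with a stated time of 48 h (on this read-out lower numbers stand for stronger inhibition and higher numbers for weaker inhibition), the lowest of the three numbers measured. Compound 2, `CCOC(=O)C1=C(N/N=C(/Br)c2ccccc2)Nc2[nH]nc(C)c2C1c1ccc(N(C)C)cc1`, gives 78400 nM, and compound 3, `CCOC(=O)C1=C(N/C=N/c2ccc(C)cc2)Nc2[nH]nc(C)c2C1c1ccc(N(C)C)cc1`, gives 50500 nM. Both differ from compound 1 only in the group carried on the amine nitrogen of the shared core: an 8.0-fold higher number from compound 1 to compound 2 (0.91 log units; beyond the scatter), and a 5.2-fold higher number from compound 1 to compound 3 (0.71 log units; beyond the scatter). Between those two the change is small, a 1.6-fold lower number from compound 2 to compound 3 (0.19 log units; within the scatter).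

Compound 4, `CCOC(=O)C1=C(N)Nc2[nH]nc(C)c2C1c1ccc(N(C)C)cc1`, strips that position bare: a hydrogen atom in place of a group of 8 heavy atoms (5 carbon, 1 nitrogen, 2 oxygen; no ring), on an amine nitrogen. Among the measured compounds shown here, no measured step removes the group outright, so the closest guide is that the two exchanges at the same nitrogen both raised the number beyond the scatter. It is therefore expected that compound 4 also shows a higher number than compound 1, with a modest step, a 3.1-fold higher number from compound 1 to compound 4 (0.49 log units; beyond the scatter). The estimate for compound 4 is 30000 nM, with a range from 8000 nM to 120000 nM.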

Compound 4, half-maximal inhibitory concentration: 5060 nM
Estimate against measurement, compound 4: 5.9-fold (0.77 log units) above, outside the stated range (below it).
By their numbers in this assay, from the lowest: compounds 4 and 1 (each within the scatter of the next); then compounds 3 and 2 (each within the scatter of the next).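

Hydrogen on this amine nitrogen gives a number that cannot be told apart from that of compound 1 (a 1.9-fold lower number from compound 1 to compound 4 (0.28 log units; within the scatter)), so the group of 8 heavy atoms in compound 1 is not needed to reach this level. The earlier compounds showed only that the two groups carrying a six-membered aromatic ring sat above compound 1, and the bare nitrogen now gives a second reference point (a 10-fold lower number from compound 3 to compound 4 (1.00 log units; beyond the scatter); a 15-fold lower number from compound 2 to compound 4 (1.19 log units; beyond the scatter)), so among these four compounds the higher numbers go with those two ring-bearing groups. Nothing measured here explains why these groups differ at this nitrogen.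

On these data alone, whether a small group such as methyl or acetyl on the same nitrogen would keep the number at this level remains open. So does the effect of a longer alkyl chain or a carboxylic acid there.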